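The compounds below may be only part of what the source reports. "The series", "measured", "known", "first", "only" and "open" are said of these compounds alone.

Compound 1 `CC(c1ccc(-c2ccccc2)c(F)c1)c1nnc2n1N=C(c1ccc(Cl)cc1Cl)CS2` gives 4200 nM in a functional assay on Hep 3B2 cells (Homo sapiens) for inhibition, read by sulforhodamine B assay, with a stated time of 72 h; a higher number here means a weaker inhibitor, a lower number a stronger inhibitor.
Compound 2 `COc1ccc(C2=Nn3c(nnc3C(C)c3ccc(-c4ccccc4)c(F)c3)SC2)cc1` gives 3500 nM in this assay.
Compound 3 `CC(c1ccc(-c2ccccc2)c(F)c1)c1nnc2n1N=C(c1ccc(Br)cc1)CS2` gives 1500 nM in this assay.

Of the three measured compounds, compound 3 has the lowest number. Both steps leading to it, a 2.8-fold lower number from compound 1 to compound 3 (0.45 log units; beyond the scatter) and a 2.3-fold lower number from compound 2 to compound 3 (0.37 log units; beyond the scatter), are modest yet beyond the scatter, so on these numbers compound 3 is the strongest inhibitor of the set. The remaining pair, compound 1 and compound 2, lie within the scatter of each other, as a 1.2-fold lower number from compound 1 to compound 2 (0.08 log units; within the scatter) shows.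

Compound 4 `CC(c1ccc(-c2ccccc2)c(F)c1)c1nnc2n1N=C(c1ccc(F)cc1)CS2` differs from compound 3 in one place: fluoro in place of bromo on an aromatic carbon. Going by the values given here, no measured step exchanges one halogen for another at this position. Among the compounds with values here, the steps that bear on it are a 2.3-fold lower number from compound 2 to compound 3 (0.37 log units; beyond the scatter) and a 2.8-fold lower number from compound 1 to compound 3 (0.45 log units; beyond the scatter), both modest and both ending at the 4-bromophenyl of compound 3. Leaving that group is therefore expected to cost something, but only a little, and a result within the scatter cannot be ruled out. Compound 4 is estimated at 2500 nM in this assay, with a range of 1000 nM to 6000 nM. The expected step is a 1.7-fold higher number from compound 3 to compound 4 (0.22 log units; within the scatter).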

Compound 4, half-maximal inhibitory concentration: 2600 nM
Beside the measured number, compound 4's estimate is 1.0-fold (0.02 log units) below it; the measured number falls inside the stated range.
By their numbers in this assay, from the lowest: compounds 3, 4, 2 and 1 (each within the scatter of the next, the first and the last beyond it).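

In this assay, going by these compounds alone, the change from 4-bromophenyl to 4-fluorophenyl is the first exchange of one halogen for another at this position, and a 1.7-fold higher number from compound 3 to compound 4 (0.24 log units; within the scatter) is a step that stays within the scatter. Compound 4 also shows a 1.3-fold lower number from compound 2 to compound 4 (0.13 log units; within the scatter) and a 1.6-fold lower number from compound 1 to compound 4 (0.21 log units; within the scatter) as steps within the scatter, so it does not separate from any of the other three compounds, although compound 3 stands apart from compound 1 and compound 2. No measurement shown here accounts for these values.

The compounds shown leave open whether an amine, a carboxylic acid or a longer alkoxy chain at this position would move the number further than the groups seen so far. They also leave open how an unsubstituted phenyl would compare with these four compounds.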